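A Methoxyphenyl Swap at the Saturated Ring Carbon

This account rests on a few compounds, and the source may have more. Where it says the series, first, only, none or still open, it means among the compounds named here.

Measured so far:
compound 1, `CC1=C(C(=O)Nc2ccc(Br)cc2)C(c2ccc(Cl)cc2Cl)N=C(SCc2ccccc2Cl)N1`: 38.1%
compound 2, `CC1=C(C(=O)Nc2ccc(Br)cc2)C(c2ccc(Cl)cc2Cl)N=C(SCc2ccc(Cl)cc2)N1`: 39.7%
compound 3, `CC1=C(C(=O)Nc2ccc(Br)cc2)C(c2ccc(Cl)cc2Cl)N=C(SCc2ccc(F)cc2)N1`: 40.7%

All three were tested in a functional assay on the whole organism (artery, strain albino) with Rattus norvegicus as the target, with a stated time of 360 min, at a dose of 10 mg/kg by the oral route; a higher number here means more inhibition at the dose given (going by the name of the read-out), a lower number less inhibition. Compound 1 stands lowest of the three, yet the steps of a number 1.6 percentage points higher from compound 1 to compound 2 (within the scatter) and a number 2.6 percentage points higher from compound 1 to compound 3 (within the scatter) are within the scatter, as is a number 1 percentage points higher from compound 2 to compound 3 (within the scatter), so the three cannot be ordered. Compound 4 `COc1ccc(C2N=C(SCc3ccccc3Cl)NC(C)=C2C(=O)Nc2ccc(Br)cc2)cc1` alters compound 1 elsewhere: 4-methoxyphenyl in place of 2,4-dichlorophenyl on a saturated ring carbon. Every measured step touched the group on the saturated chain carbon bound to a sulfur, or exchanged fluoro for chloro on an aromatic carbon, and none left the scatter. For the measured compounds named here, there is no measured precedent for a change at the saturated ring carbon. In this assay the expected step is a number 1.1 percentage points lower from compound 1 to compound 4 (within the scatter), nothing beyond the scatter. The estimate for compound 4 is 37%, expected to lie between 20% and 54%.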

Compound 4, a percentage reported as inhibition, in the whole organism at one dose (the size of the read-out at that dose, not a potency): 20.6%
Estimate against measurement, compound 4: 16.4 percentage points above; low and high end bracket the measured number.
By their numbers in this assay, from the lowest: compound 4; then compounds 1, 2 and 3 (each within the scatter of the next).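

The group on the saturated ring carbon matters in this assay: 4-methoxyphenyl in place of 2,4-dichlorophenyl gives a number 17.5 percentage points lower from compound 1 to compound 4 (beyond the scatter). For the compounds shown here, this is the only step in the set that lies beyond the scatter, whereas the changes on the saturated chain carbon bound to a sulfur stayed within it. Nothing measured here accounts for the loss of inhibition.

This one swap removes both chloro groups and brings in the methoxy together, so the compounds shown cannot separate the two changes. From the compounds shown here alone, what an unsubstituted phenyl or a 4-chlorophenyl on this carbon would give remains open.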